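Compound 4 after a small measured step

The source may hold more compounds than are shown below. What is called first, only, known or untested is meant among the compounds shown, and "the series" means these compounds.

Measured in a functional assay on MGC-803 cells (Homo sapiens) for antiproliferative activity, read by MTT assay, with a stated time of 72 h; on this read-out lower numbers stand for stronger inhibition and higher numbers for weaker inhibition:
Compound 1 `CCCSc1nc(N/N=C/c2c[nH]c3ccccc23)c2nnn(Cc3ccccc3)c2n1`: 7410 nM
Compound 2 `CCCSc1nc(N/N=C/c2ccc(N(C)C)cc2)c2nnn(Cc3ccccc3)c2n1`: 13100 nM
Compound 3 `CCCSc1nc(N/N=C(\C)c2ccccc2)c2nnn(Cc3ccccc3)c2n1`: 25400 nM

Compound 3 stands within the scatter of compound 2 and beyond the scatter above compound 1. Compound 4 `CCCSc1nc(N/N=C/c2ccccc2F)c2nnn(Cc3ccccc3)c2n1` carries this change from compound 3: a group of 9 heavy atoms (7 carbon, 1 nitrogen, 1 fluorine; one six-membered aromatic ring of carbon only) in place of a group of 9 heavy atoms (8 carbon, 1 nitrogen; one six-membered aromatic ring of carbon only), on a nitrogen on an aromatic ring and the core stays the same. Within the data shown here, one measured step bears on this, a 1.8-fold higher number from compound 1 to compound 2 (0.25 log units; within the scatter), a swap on a carbon with a double bond to nitrogen inside the part exchanged here. No step beyond the scatter is therefore expected, and the estimated change is a 1.8-fold lower number from compound 3 to compound 4 (0.26 log units; within the scatter) in this read-out. The data hold no direct measure of this exchange. Compound 4 is estimated at 14000 nM, with an expected range from 5000 nM to 40000 nM in this assay when measured.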

Compound 4, half-maximal inhibitory concentration: > 64000 nM
Compound 4: a limit, no number (the forecaster's own chance of this, stated with the estimate: 10%); middle value at least 4.5-fold (0.66 log units) from the limit.
By their numbers in this assay, from the lowest: compounds 1, 2 and 3 (each within the scatter of the next, the first and the last beyond it). At a limit, above all of these: compound 4.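

In this assay compound 4 gives > 64000 nM, which is a limit and not a number. Exchanging the group on a nitrogen on an aromatic ring therefore moves the read-out beyond the scatter (an at least 2.5-fold higher number from compound 3 to compound 4 (0.40 log units; beyond the scatter)). On the carbon with a double bond to nitrogen, 2-fluorophenyl also gives steps beyond the scatter (an at least 4.8-fold higher number from compound 2 to compound 4 (0.68 log units; beyond the scatter)) and (an at least 8.6-fold higher number from compound 1 to compound 4 (0.93 log units; beyond the scatter)), unlike 4-(dimethylamino)phenyl in place of 1H-indol-3-yl.

The data do not separate the part played by the fluorine from that of the methyl present in compound 3. On these data alone, how a hydroxyl or an amine in place of the fluorine would read remains open.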